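Open-chain diol in place of the sugar ring

A few compounds are considered here, and "the series" means these few. Any claim that something is new, unique, unknown or untested is made for them only; others in the source may bear on it.

Of the compounds shown here, two of this core have been measured. In a functional assay on SH-SY5Y cells (Homo sapiens) for cytotoxicity, read by MTT assay, with a stated time of 72 h (a higher number here means a weaker inhibitor, a lower number a stronger inhibitor), compound 1 `O=C1c2c[n+]([O-])c3ccccc3c2C(=O)c2c1c1ccccc1n2CCCCn1ccnc1` gives 130 nM, and compound 2 `O=C1c2c[n+]([O-])c3ccccc3c2C(=O)c2c1c1ccccc1n2Cc1cn([C@@H]2C[C@H](O)[C@@H](CO)O2)nn1` gives 150 nM; compound 2 does not separate from compound 1 beyond the scatter, so no ranking follows. Compound 3 `O=C1c2c[n+]([O-])c3ccccc3c2C(=O)c2c1c1ccccc1n2Cc1cn(CC(O)CO)nn1` carries the change (2,3-dihydroxypropyl in place of 4-hydroxy-5-(hydroxymethyl)oxolan-2-yl on an aromatic nitrogen). For the measured compounds named here, no measured pair shows such a step, and the two numbers in hand give no direction to read off. The step of a 1.3-fold higher number from compound 2 to compound 3 (0.12 log units; within the scatter) is therefore expected to stay within the scatter. For compound 3 in this assay a value of 200 nM is estimated, with a range from 80 nM to 500 nM.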

Compound 3, half-maximal inhibitory concentration: > 1000 nM
Compound 3 was reported as a limit; the forecaster's own chance of this, stated with the estimate: 5%; middle value at least 5.0-fold (0.69 log units) away from the limit.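

In this assay compound 3 stands at > 1000 nM, a limit of the assay and not a number: the limit of > 1000 nM in this assay, at which 1 of the 3 values shown sits.

The group on this aromatic nitrogen therefore matters: 2,3-dihydroxypropyl in place of 4-hydroxy-5-(hydroxymethyl)oxolan-2-yl gives an at least 6.6-fold higher number from compound 2 to compound 3 (0.82 log units; beyond the scatter). 1-(2,3-Dihydroxypropyl)-1H-1,2,3-triazol-4-yl in place of 3-(1H-imidazol-1-yl)propyl gives an at least 7.6-fold higher number from compound 1 to compound 3 (0.88 log units; beyond the scatter), so the earlier lack of separation does not extend to this side chain.

Going by these compounds, the full size of both steps stays open, as does whether the ring or its hydroxyl groups account for the loss. A cyclopentyl ring without hydroxyl groups on this nitrogen would separate the two.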